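The source may hold more compounds than are shown below. What is called first, only, known or untested is meant among the compounds shown, and "the series" means these compounds.

Measured so far in an assay on isolated protein for inhibition of Dihydrofolate reductase (Mus musculus), at pH 7.20; a lower number here means a less potent compound, a higher number a more potent compound, by a factor of ten per unit of this negative logarithm:
compound 1, `CC1(C)N=C(N)N=C(N)N1c1ccccc1S`: 6.86
compound 2, `CC1(C)N=C(N)N=C(N)N1c1ccccc1F`: 4.39

Compound 2 stands lowest of the two measured, far under compound 1. Compound 3, `CCc1ccccc1N1C(N)=NC(N)=NC1(C)C`, differs from compound 2 by ethyl in place of fluoro on an aromatic carbon. Within the data shown here, the one measured step at this place is a number 2.47 log units lower from compound 1 to compound 2 (beyond the scatter), a large loss on going to fluoro. Among the measured compounds shown here, replacing fluoro by ethyl is therefore expected to recover a good part of that loss, though the ethyl has no measured counterpart here, so the range is wide. For compound 3 the expected value in this assay is 6, between 5 and 7. The expected step is a number 1.61 log units higher from compound 2 to compound 3 (beyond the scatter).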

Compound 3, logarithm of the reciprocal of the active concentration, log(1/C): 3.38
For compound 3 the middle estimate is 2.62 log units above the measured one; the measured number lies below the stated range.
By their numbers in this assay, from the lowest: compound 3; then compound 2; then compound 1.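

In this assay, ethyl on this aromatic carbon sits lowest of the three groups shown, not between fluoro and sulfanyl: it falls short of fluoro (a number 1.01 log units lower from compound 2 to compound 3 (beyond the scatter)) and further short of sulfanyl (a number 3.48 log units lower from compound 1 to compound 3 (beyond the scatter)). Across these three compounds, the added heavy atom of ethyl over fluoro brings no gain, and sulfanyl remains the only group here with a high number. No measurement on hand explains this order.

Going by these compounds, whether a hydroxyl, an amine or a methyl at this place comes near compound 1 remains open.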